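This account rests on a few compounds, and the source may have more. Where it says the series, first, only, none or still open, it means among the compounds named here.

Going by the values given here, in a functional assay (mast cells) for inhibition, with Rattus norvegicus as the target (on this read-out lower numbers stand for an effect already at smaller amounts and higher numbers for an effect only at larger amounts of compound), three compounds have numbers so far. Compound 1 `CCOC(=O)c1cnc2n(c1=O)C(C)CC/C2=N\Nc1cccc(C(=O)O)c1` gives 740000 nM, compound 3 `CC1C/C(=N\Nc2ccccc2)c2ncc(C(=O)O)c(=O)n2C1` gives 13000 nM, and compound 2 `O=C(O)c1cnc2n(c1=O)CCC/C2=N\Nc1ccccc1` gives 2900 nM, the lowest of the three. Compound 4 `CC1CCn2c(ncc(C(=O)O)c2=O)/C1=N/Nc1ccccc1` has not yet been measured. It comes from compound 2 through a single change, methyl in place of hydrogen on a saturated ring carbon.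

Among the compounds with values here, only one measured step bears on this change, the same swap made on a different saturated ring carbon: a 4.5-fold higher number from compound 2 to compound 3 (0.65 log units; beyond the scatter). That modest rise lies beyond the scatter. Compound 1 differs from compound 2 in more than one place, so it offers no clean comparison. A single step at another carbon is thin evidence, so a smaller rise in the same direction seems the best guess, and no real change remains possible. The expected step is a 2.4-fold higher number from compound 2 to compound 4 (0.38 log units; beyond the scatter). Compound 4 is estimated at 7000 nM, with an expected range from 2000 nM to 25000 nM.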

Compound 4, half-maximal effective concentration: 5400 nM
Beside the measured number, compound 4's estimate is 1.3-fold (0.11 log units) above it, within the range that was stated.
By their numbers in this assay, from the lowest: compounds 2 and 4 (each within the scatter of the next); then compound 3; then compound 1.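

In this assay, methyl in place of hydrogen on this saturated ring carbon, three ring bonds from the ring nitrogen, gives a 1.9-fold higher number from compound 2 to compound 4 (0.27 log units; within the scatter) and so leaves compound 4 within the scatter of compound 2. The same swap on a different saturated ring carbon gave a 4.5-fold higher number from compound 2 to compound 3 (0.65 log units; beyond the scatter) and lies beyond the scatter, so the two placements of the methyl do not read alike. Nothing available here accounts for that difference between the two carbons.

The compounds shown leave open what an ethyl, a longer chain or an amine on this same carbon would do to the number. They also leave open whether this methyl would give a similar step on a core carrying other groups, such as that of compound 1.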